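Aryl urea variation on the shared core, T47D growth

The source may report more compounds than this note shows. Statements on the series, on what has been measured and on what is new or still open speak of the compounds shown alone.

Measured compounds:
compound 1, `COc1cc2cc(Oc3ccc(NC(=O)Nc4ccc(C)cc4)cc3)c(C)nc2cc1OC`, 101%
compound 2, `COc1cc2cc(Oc3ccc(NC(=O)Nc4ccc(C(F)(F)F)cc4)cc3)c(C)nc2cc1OC`, 57.5%
compound 3, `COc1cc2cc(Oc3ccc(NC(=O)Nc4cccc(C(F)(F)F)c4)cc3)c(C)nc2cc1OC`, 27.8%

In a functional assay on T47D cells (Homo sapiens) for inhibition, read by sulforhodamine B assay, with a stated time of 48 h, tested at 10 uM (a lower number here means a stronger effect, a higher number a weaker effect of the compound at the concentration tested), compound 3 gives the lowest of the three numbers, and compound 1 gives the highest. The steps show this clearly: a number 43.5 percentage points lower from compound 1 to compound 2 (beyond the scatter), a number 73.2 percentage points lower from compound 1 to compound 3 (beyond the scatter) and a number 29.7 percentage points lower from compound 2 to compound 3 (beyond the scatter) all point the same way, with each replacement of the aryl group on the amide-type nitrogen lowering the number beyond the scatter.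

Compound 4, `COc1cc2cc(Oc3ccc(NC(=O)Nc4ccc(Cl)c(Cl)c4)cc3)c(C)nc2cc1OC`, has not been measured. It differs from compound 3 in one place: 3,4-dichlorophenyl in place of 3-(trifluoromethyl)phenyl on an amide-type nitrogen. Both measured steps that touch this part of the structure, from compound 1 and from compound 2 to compound 3, lowered the number, the first strongly and the second modestly, but none of them introduces two chlorine atoms, so no direct guide exists. The expectation is therefore for little change beyond the scatter, with a number 0.2 percentage points higher from compound 3 to compound 4 (within the scatter) as the expected step. Compound 4 is estimated to give 28%, between 8% and 55%.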

Compound 4, a percentage reported as activity, at one concentration (the size of the read-out at that concentration, not a potency): 60.9%
For compound 4 the middle estimate is 32.9 percentage points below the measured one; measured number above the stated range.
By their numbers in this assay, from the lowest: compound 3; then compounds 2 and 4 (each within the scatter of the next); then compound 1.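

In this assay the low number of compound 3 does not carry over to every substituted phenyl on the amide-type nitrogen: 3,4-dichlorophenyl in place of 3-(trifluoromethyl)phenyl gives a number 33.1 percentage points higher from compound 3 to compound 4 (beyond the scatter). The same group in place of 4-(trifluoromethyl)phenyl gives a number 3.4 percentage points higher from compound 2 to compound 4 (within the scatter), so these two exchanged aryl groups cannot be told apart in this read-out. Set against 4-methylphenyl, it still gives a number 40.1 percentage points lower from compound 1 to compound 4 (beyond the scatter), so the dichloro compound keeps part of the drop seen with the trifluoromethyl compounds.

Nothing measured here accounts for the gap between the 3,4-dichlorophenyl and 3-(trifluoromethyl)phenyl groups. As far as these compounds go, whether a methoxy group, an amine or a carboxylic acid on this phenyl ring would reach the number of compound 3 remains open.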